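Aryl exchange on the shared core: compound 1 to compound 4

This account rests on a few compounds, and the source may have more. Where it says the series, first, only, none or still open, it means among the compounds named here.

Notes on the series in an assay on CHO cells for displacement of a labelled ligand from adenosine receptor A1 (Homo sapiens), read by scintillation counting, tested at 10 uM; a higher number here means more inhibition at the concentration tested (going by the name of the read-out), a lower number less inhibition. Compound 1 `CC(C)(C)Cc1c(-c2ccoc2)sc(N)c1C(=O)c1ccc(Cl)cc1` gives 1% in this assay. Compound 2 `CC(C)(C)Cc1c(/C=C/c2ccc(Cl)cc2)sc(N)c1C(=O)c1ccc(Cl)cc1` gives 1%, and compound 3 `CC(C)(C)Cc1csc(N)c1C(=O)c1cccc(C(F)(F)F)c1` gives 1%. Within the data shown here, the one single-point step measured so far, no change at the digits printed from compound 1 to compound 2 (within the scatter), exchanges the furan-3-yl for 2-(4-chlorophenyl)ethenyl on an aromatic carbon and leaves the read-out where it was. Compound 1 thus stands level with compound 2 and with compound 3 at the digits shown; nothing in the set rises out of the scatter.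

Compound 4 `CC(C)(C)Cc1c(-c2ccccc2)sc(N)c1C(=O)c1ccc(Cl)cc1` is the next variation at the same place. The change is phenyl in place of furan-3-yl on an aromatic carbon. Among the measured compounds shown here, the step that bears on it is the one from compound 1 to compound 2, which swapped the same furan-3-yl for a different aromatic group without any movement in this assay. For the measured compounds named here, compound 3, carrying no group at that carbon at all, sits at the same low level, though no single-point step links it to compound 1. On these numbers no step beyond the scatter is expected in this assay, in either direction, so a number 1 percentage points higher from compound 1 to compound 4 (within the scatter) is estimated to be flat.

Compound 4 is therefore expected to give 2%, within a range from -8% to 14%.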

Compound 4, a percentage reported as inhibition, at one concentration (the size of the read-out at that concentration, not a potency): 1%
Compound 4: middle estimate off by 1 percentage points, on the high side, and the stated range covers the measured number.
By their numbers in this assay, from the lowest: compounds 1, 2, 3 and 4 (each within the scatter of the next).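

Exchanging furan-3-yl, with its hydrogen-bond acceptor, for phenyl, an aromatic ring of carbon only, gives no change at the digits printed from compound 1 to compound 4 (within the scatter) in this assay, so at this place the loss of the ring oxygen and the change from a five-membered to a six-membered aromatic ring do not register in the read-out. Phenyl in place of 2-(4-chlorophenyl)ethenyl gives no change at the digits printed from compound 2 to compound 4 (within the scatter), which links all three groups on the aromatic carbon next to the ring sulfur by measured steps, and none of these steps leaves the scatter. No further data bear on why this position stays flat.

Still open, as far as these compounds go, is whether any group at this carbon can lift the read-out out of the scatter, for example a primary amine on a short chain, a carboxylic acid or a longer alkyl chain. Also open, from the compounds shown here alone, is whether the flat read-out holds when the change is made elsewhere on the shared core, such as an acetamide in place of the amino group or a smaller alkyl chain in place of the neopentyl group.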